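The compounds below may be only part of what the source reports. "The series", "measured", "known", "first", "only" and "open" are said of these compounds alone.

Working notes on the series. In a functional assay on HL-60 cells (Homo sapiens) for cytotoxicity, read by MTT assay, with a stated time of 4 days (a higher number here means a weaker inhibitor, a lower number a stronger inhibitor), compound 1 `Cc1c(O)ccc2c1[C@H](Cn1cc(-c3ccc(C(F)(F)F)cc3)nn1)[C@@]13CC(=O)[C@@](C)(CC[C@@H]21)C3` gives > 20000 nM, which is a limit of the assay and not a number. Compound 2 `Cc1ccc(-c2cn(C[C@H]3c4c(ccc(O)c4C)[C@@H]4CC[C@@]5(C)C[C@]43CC5=O)nn2)cc1` likewise gives only a limit, > 20000 nM. The change between them, (methyl in place of trifluoromethyl on an aromatic carbon), therefore makes a step that the two limits leave unreadable from compound 1 to compound 2, and nothing about its size can be read, as the limit of > 20000 nM in this assay, at which 3 of the 3 values shown sit, records.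

Compound 3 `C=C1C[C@]23C[C@@]1(O)CC[C@@H]2c1cccc(C)c1[C@@H]3Cn1cc(-c2ccc(C(F)(F)F)cc2)nn1` also returns a limit in this assay, > 20000 nM. The difference between the core of compound 3 and the core of compound 1 is not broken down here.

Compound 4 `C=C1C[C@]23C[C@@]1(O)CC[C@@H]2c1cccc(C)c1[C@@H]3Cn1cc(-c2ccc(C)cc2)nn1` has not been measured. Among the measured compounds shown here, it differs from compound 3 by methyl in place of trifluoromethyl on an aromatic carbon, the same change as the one from compound 1 to compound 2, in the same place. Since that earlier step was unreadable between two limits, and since all three values shown sit at the limit noted in the limit of > 20000 nM in this assay, at which 3 of the 3 values shown sit, the step from compound 3 to compound 4 is expected to be a step that the limit leaves unreadable from compound 3 to compound 4. Compound 4 is estimated to give 30000 nM in this assay, most likely as a limit again.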

Compound 4, half-maximal inhibitory concentration: > 20000 nM
Compound 4: a limit, no number; the forecaster's own chance of this, stated with the estimate: 85%; the middle value does not contradict the limit.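

Compound 4 gives > 20000 nM in this assay, which is a limit and not a number. No step can be read from compound 3 to compound 4, and the series stays at one limit: the limit of > 20000 nM in this assay, at which 4 of the 4 values shown sit.

The compounds shown leave open what any of the four would give as an actual number in this assay, and whether trifluoromethyl and methyl differ on either core.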